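The source may hold more compounds than are shown below. What is called first, only, known or untested is meant among the compounds shown, and "the series" means these compounds.

Working notes on the series. Three members have been measured in a functional assay on U-87MG ATCC cells (Homo sapiens) for cytotoxicity, read by MTT assay, with a stated time of 72 h; on this read-out lower numbers stand for stronger inhibition and higher numbers for weaker inhibition. Compound 1 `COc1cc2c(Oc3ccc(NC(=O)c4nnn(-c5ccccc5)c4C)cc3F)ccnc2cc1OCCCN1CCCC1` gives 1000 nM in this assay. Among the compounds with values here, compound 2 `COc1cc2c(Oc3ccc(NC(=O)c4nnn(-c5ccccc5)c4C)cc3F)ccnc2cc1OCCCN1CCCCC1` gives 1130 nM; the only change there is a 1.1-fold higher number from compound 1 to compound 2 (0.05 log units; within the scatter). Compound 3 `COc1cc2c(Oc3ccc(NC(=O)c4nnn(-c5ccccc5C)c4C)cc3F)ccnc2cc1OCCCN1CCC(C)CC1` gives 2160 nM, the highest number of the three measured; against compound 2 the gap is within the scatter, against compound 1 it lies just beyond it.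

The step under consideration leads to compound 4 `COc1cc2c(Oc3ccc(NC(=O)c4nnn(-c5ccccc5)c4C)cc3F)ccnc2cc1OCCCN1CCC(C)CC1`, which is not yet measured in this assay. Its difference from compound 3 is hydrogen in place of methyl on an aromatic carbon, ortho to a large group; cut one bond further out, 2-methylphenyl becomes phenyl.

Within the data shown here, no measured step shows this change alone. Among the measured compounds shown here, the one measured step, from compound 1 to compound 2, concerns the other end of the molecule and is within the scatter, so it says nothing about the aryl methyl. Compound 2 and compound 3 differ in two places at once, the aryl methyl and the methyl on the piperidine, and their numbers are within the scatter of each other, so neither change can be credited with the higher number of compound 3.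

Compound 4 is therefore expected to land near the measured members, with a step of a 1.4-fold lower number from compound 3 to compound 4 (0.16 log units; within the scatter), an expected estimate of 1500 nM, in a range from 700 nM to 3500 nM.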

Compound 4, half-maximal inhibitory concentration: 1240 nM
For compound 4 the middle estimate is 1.2-fold (0.08 log units) above the measured one; measured number inside the range.
By their numbers in this assay, from the lowest: compounds 1, 2, 4 and 3 (each within the scatter of the next, the first and the last beyond it).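

Within the data shown here, the step of a 1.7-fold lower number from compound 3 to compound 4 (0.24 log units; within the scatter) in this assay is the first to isolate hydrogen in place of methyl on an aromatic carbon, ortho to a large group; it lies within the scatter, so the change from 2-methylphenyl to phenyl has no readable effect on this read-out in this pair. Among these compounds, the new compound also isolates the methyl on the saturated ring carbon, with a 1.1-fold higher number from compound 2 to compound 4 (0.04 log units; within the scatter), and extends the comparison of the amines to 4-methylpiperidin-1-yl in place of pyrrolidin-1-yl, with a 1.2-fold higher number from compound 1 to compound 4 (0.09 log units; within the scatter); both steps lie within the scatter, so none of the single changes read so far moves the number beyond it. No evidence at hand bears on the origin of these small steps.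

The compounds shown leave open whether a methoxy group or a chlorine on that same aromatic carbon, ortho to a large group, would give a step beyond the scatter. As far as these compounds go, it also remains open whether a morpholin-4-yl group in place of the 4-methylpiperidin-1-yl, or a longer chain leading to it, would do so.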